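Adding one hydroxymethyl to compound 2

The source may report more compounds than this note shows. Statements on the series, on what has been measured and on what is new or still open speak of the compounds shown alone.

Compound 1 `C[C@H]1O[C@@H]2C[C@@H](O)[C@@]1(O)c1c2c(O)c(C(N)=O)c2ncoc12` measures 6800 nM 
Compound 2 `C[C@H]1O[C@@H]2C[C@@H](O)[C@@]1(O)c1c2c(O)c(C(N)=O)c2nc([C@@H](O)CO)oc12` measures 5600 nM 

Both numbers come from a functional assay on HCT-116 cells (Homo sapiens) for inhibition, read by CCK-8 assay, with a stated time of 72 h (a lower number here means a stronger inhibitor, a higher number a weaker inhibitor), and compound 2 stands within the scatter of compound 1, so neither can be ranked ahead of the other. Compound 3 `C[C@H]1O[C@@H]2C[C@@H](O)[C@@]1(O)c1c2c(O)c(C(N)=O)c2nc([C@@H](O)[C@@H](O)CO)oc12` differs from compound 2 in one place. The change is hydroxymethyl in place of hydrogen on a saturated chain carbon bound to an oxygen on a saturated carbon and a saturated chain carbon and it puts hydroxymethyl in place of hydrogen on a saturated chain carbon, turning 1,2-dihydroxyethyl into 1,2,3-trihydroxypropyl. Among the measured compounds shown here, only one measured step bears on this. Putting 1,2-dihydroxyethyl in place of hydrogen on an aromatic carbon gave a 1.2-fold lower number from compound 1 to compound 2 (0.08 log units; within the scatter) and so stayed inside the scatter. For the measured compounds named here, a single step is thin evidence, and no compound carrying the longer chain has been measured yet. In this assay no shift beyond the scatter is therefore expected, in either direction. The expected step is a 1.0-fold lower number from compound 2 to compound 3 (0.01 log units; within the scatter) by this estimate. The estimate for compound 3 is 5500 nM with 2500 nM to 12000 nM as the expected range.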

Compound 3, half-maximal inhibitory concentration: 4400 nM
Beside the measured number, compound 3's estimate is 1.3-fold (0.10 log units) above it; the measured number falls inside the stated range.
By their numbers in this assay, from the lowest: compounds 3, 2 and 1 (each within the scatter of the next).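

In this assay, extending 1,2-dihydroxyethyl to 1,2,3-trihydroxypropyl gave a 1.3-fold lower number from compound 2 to compound 3 (0.10 log units; within the scatter), so hydroxymethyl in place of hydrogen on this saturated chain carbon produced no shift that can be told apart from ordinary variation between repeated measurements. The whole side chain, set in place of hydrogen on an aromatic carbon, gave a 1.5-fold lower number from compound 1 to compound 3 (0.19 log units; within the scatter), so even the longer chain, compared directly with the compound that lacks it, stays inside the scatter and the three compounds cannot be put in a firm order. No other data accompany these numbers that could explain how little the chain changes the reading in these cells.

Still open, going by these compounds, is whether any group at this place can move the number beyond the scatter, for instance a longer chain with further hydroxyl groups, an amine or a carboxylic acid in place of the final hydroxymethyl. A simple methyl at the same carbon would also show whether the added hydroxyl matters at all, or only the added length.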